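The source may hold more compounds than are shown below. What is called first, only, known or untested is meant among the compounds shown, and "the series" means these compounds.

Measured compounds in a physicochemical assay for solubility, read by HPLC, using the shake flask method, with a stated time of 2 h, at pH 2; on this read-out higher numbers stand for higher solubility and lower numbers for lower solubility:
- compound 1 `N#Cc1ccc(-c2cnc(N)c(-c3ccc(N)nc3)n2)cc1` gives 208000 nM
- compound 2 `Nc1ncc(-c2ccc(C(=O)N3CC[C@H](O)C3)cc2)nc1-c1ccc(C(F)(F)F)cc1` gives 93000 nM
- compound 3 `CNC(=O)c1ccc(-c2nc(-c3ccc(C(N)=O)cc3)cnc2N)cc1` gives 186000 nM

Compound 2 stands lowest of the three numbers in this assay. Its nearest neighbour is compound 3, whose number is higher by an amount that lies within the usual scatter, so the two cannot be ranked against each other. Compound 1 sits furthest off, its number higher by an amount just beyond the scatter.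

Compound 4 `Nc1ncc(-c2ccc(C(=O)N3CC[C@@H](O)C3)cc2)nc1-c1ccc(C(F)(F)F)cc1` is the next entry for this assay. Its relation to compound 2: the two compounds have the same atoms and bonds and differ only in configuration as drawn: 1 of 1 stereo elements differ; a stereocentre at a saturated ring carbon is drawn S in compound 2 and R in compound 4.

Among the compounds with values here, no step between measured compounds is available for this kind of change. Since nothing leaves and nothing enters, and only the drawn configuration at one saturated ring carbon differs, no step beyond the scatter is expected in either direction; the value of compound 4 is expected to sit essentially where compound 2 sits. The estimated step from compound 2 to compound 4 is no change at the digits printed from compound 2 to compound 4 (within the scatter). Compound 4 is estimated at 93000 nM, with a range from 50000 nM to 170000 nM, because compound 2 gives 93000 nM.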

Compound 4, solubility: 103000 nM
Compound 4: the middle estimate sits 1.1-fold (0.04 log units) below what was measured; low and high end bracket the measured number.
By their numbers in this assay, from the lowest: compounds 2, 4, 3 and 1 (each within the scatter of the next, the first and the last beyond it).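

Inverting the stereocentre at the saturated ring carbon gives a 1.1-fold higher number from compound 2 to compound 4 (0.04 log units; within the scatter) in this assay, so this read-out does not separate the S and R forms drawn here. Within the data shown here, the earlier compounds offered no step between measured structures, which makes this the only change so far that can be read on its own. The comparison involves a single difference, with no group leaving or entering: the fact that compounds 2 and 4 differ only in the configuration as drawn.

As far as these compounds go, whether the read-out stays equally indifferent to configuration with another group on that saturated ring carbon, such as a carboxylic acid or a methoxy group, remains open. Also open, from the compounds shown here alone, is whether the two forms stay within the scatter of each other on any read-out other than this assay.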